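Swapping tert-butyl for phenyl next in the series

The source may report more compounds than this note shows. Statements on the series, on what has been measured and on what is new or still open speak of the compounds shown alone.

In an ADME assay on Caco-2 cells (Homo sapiens) for permeability, read by LC-MS, in the apical to basolateral direction, with a stated time of 60 min, at pH 6.5 (a lower number here means that the compound crosses the layer more slowly, a higher number that the compound crosses the layer faster), compound 3 `CC(C)(C)[C@@H](O)C(=O)N1[C@H](C(=O)NCc2cc(Cl)ccc2-n2cnnn2)C[C@@H]2C[C@@H]21` gives 16 10^-6 cm/s. Compound 2 `O=C(NCc1cc(Cl)ccc1-n1cnnn1)[C@@H]1C[C@@H]2C[C@@H]2N1C(=O)[C@H](O)C1CCCCC1` gives 16 10^-6 cm/s, and compound 1 `O=C(NCc1cc(Cl)ccc1-n1cnnn1)[C@@H]1C[C@@H]2C[C@@H]2N1C(=O)[C@H](O)Cn1cccn1` gives 0.45 10^-6 cm/s. Compound 3 is level with compound 2, the two together the highest of the three numbers; the step of no change at the digits printed from compound 2 to compound 3 (within the scatter) is within the scatter, whereas a 36-fold higher number from compound 1 to compound 3 (1.55 log units; beyond the scatter) and a 36-fold higher number from compound 1 to compound 2 (1.55 log units; beyond the scatter) are large. Compound 4 `O=C(NCc1cc(Cl)ccc1-n1cnnn1)[C@@H]1C[C@@H]2C[C@@H]2N1C(=O)[C@H](O)c1ccccc1` differs from compound 3 by phenyl in place of tert-butyl on a saturated chain carbon bound to a carbonyl carbon and an oxygen on a saturated carbon. Within the data shown here, the phenyl group, like the tert-butyl and cyclohexyl groups it joins in this comparison, carries no hydrogen-bond donors or acceptors, and nothing measured so far distinguishes between such groups. The step of a 1.3-fold lower number from compound 3 to compound 4 (0.12 log units; within the scatter) is therefore expected to stay within the scatter. Compound 4 is estimated at 12 10^-6 cm/s, between 5 10^-6 cm/s and 25 10^-6 cm/s.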

Compound 4, apparent permeability: 8 10^-6 cm/s
Compound 4: middle estimate off by 1.5-fold (0.18 log units), on the high side, within the range that was stated.
By their numbers in this assay, from the lowest: compound 1; then compounds 4, 2 and 3 (each within the scatter of the next).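

In this assay, a six-membered aromatic ring at this position gives a number that cannot be told apart from those of the saturated groups: a 2.0-fold lower number from compound 3 to compound 4 (0.30 log units; within the scatter) and a 2.0-fold lower number from compound 2 to compound 4 (0.30 log units; within the scatter) leave phenyl, tert-butyl and cyclohexyl level within the scatter. The (1H-pyrazol-1-yl)methyl group alone stands apart, with an 18-fold higher number from compound 1 to compound 4 (1.25 log units; beyond the scatter) now extending that gap to an aromatic carbon ring. No evidence is available to explain these numbers. Still open, on these data alone, is whether an amine or a carboxylic acid at this position would stay with the carbon-only groups or sit nearer compound 1.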